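Reversal of the enone and a methyl on compound 4

The source may hold more compounds than are shown below. What is called first, only, known or untested is meant among the compounds shown, and "the series" means these compounds.

Among the measured compounds shown here, compound 3 `COc1ccc(/C=C/C(=O)c2cc(-c3ccc(OC)c(OC)c3)n3nc(-c4ccccc4)cc3n2)cc1` gives 19300 nM in a functional assay on A549 cells (Homo sapiens) for antiproliferative activity, read by MTT assay, with a stated time of 24 h (on this read-out higher numbers stand for weaker inhibition and lower numbers for stronger inhibition), the highest of the three numbers so far; compound 2 `COc1ccc(-c2cc(/C=C/C(=O)c3ccccc3)nc3cc(-c4ccccc4)nn23)cc1OC` gives 10700 nM and compound 1 `COc1ccc(C(=O)/C=C/c2cc(-c3ccc(OC)c(OC)c3)n3nc(-c4ccccc4)cc3n2)cc1OC` gives 3900 nM in this assay. Compound 4 `COc1ccc(-c2cc(/C=C/C(=O)c3ccc(C)cc3)nc3cc(-c4ccccc4)nn23)cc1OC` carries 2-((4-methylphenyl)carbonyl)ethenyl in place of (2-(4-methoxyphenyl)ethenyl)carbonyl on an aromatic carbon. The step that bears on it is a 1.8-fold higher number from compound 2 to compound 3 (0.26 log units; within the scatter), which compound 4 in effect reverses while adding a methyl; the step of a 2.7-fold higher number from compound 1 to compound 2 (0.44 log units; beyond the scatter) concerns another position and is only indirect. Nothing beyond the scatter is therefore expected from a 1.9-fold lower number from compound 3 to compound 4 (0.29 log units; within the scatter). Compound 4 is expected at 10000 nM in this assay, with a range from 4000 nM to 25000 nM.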

Compound 4, half-maximal inhibitory concentration: 17200 nM
Estimate against measurement, compound 4: 1.7-fold (0.24 log units) below; the range from low to high includes it.
By their numbers in this assay, from the lowest: compound 1; then compounds 2, 4 and 3 (each within the scatter of the next).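

At the position on the ring with 2 nitrogen, swapping (2-(4-methoxyphenyl)ethenyl)carbonyl for 2-((4-methylphenyl)carbonyl)ethenyl leaves this assay unable to separate the two groups (a 1.1-fold lower number from compound 3 to compound 4 (0.05 log units; within the scatter)). The added methyl is equally unresolved (a 1.6-fold higher number from compound 2 to compound 4 (0.21 log units; within the scatter)), whereas 4-methylphenyl in place of 3,4-dimethoxyphenyl on the carbonyl carbon gives a separation beyond the scatter (a 4.4-fold higher number from compound 1 to compound 4 (0.64 log units; beyond the scatter)). No supporting data bear on why these numbers fall as they do.

Open, from the compounds shown here alone, is whether an amine or a carboxylic acid in place of the methyl of compound 4 would move the number beyond the scatter.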